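Shortening the butoxy chain from compound 3 to compound 4

The source may hold more compounds than are shown below. What is called first, only, known or untested is meant among the compounds shown, and "the series" means these compounds.

All four compounds share one core. Compound 1 `Oc1cc(-c2ccccc2)nc2c(O)cccc12` carries a hydroxy group on an aromatic carbon; in a functional assay on A549 cells (Homo sapiens) for cytotoxicity (a higher number here means that more compound is needed for the effect, a lower number that less compound is needed), compound 1 gives only the assay limit > 10 ug/mL. Compound 2 `Oc1cc(-c2ccccc2)nc2c(F)cccc12` gives 0.61 ug/mL in this assay, so the step of an at least 16-fold lower number from compound 1 to compound 2 (1.21 log units; beyond the scatter) is large. Compound 3 `CCCCOc1cc(-c2ccccc2)nc2ccccc12` carries a butoxy chain and in this assay compound 3 returns only the limit > 10 ug/mL. Compound 3 thus stands at the limit of > 10 ug/mL in this assay, at which 2 of the 3 values shown sit. Compound 4 `CCOc1cc(-c2ccccc2)nc2ccccc12` differs from compound 3 by hydrogen in place of ethyl on a saturated chain carbon, two bonds along the chain from an oxygen on an aromatic ring, butoxy becoming ethoxy. Among the measured compounds shown here, no measured step concerns this chain; the only measured step alters an aromatic substituent, so it gives no direction here. Compound 4 is therefore expected to stay near the limit, estimated at 10 ug/mL with a range from 3 ug/mL to 30 ug/mL. The expected step of a number no higher from compound 3 to compound 4 (the limit leaves the size open) would then lie within the scatter.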

Compound 4, half-maximal effective concentration: > 10 ug/mL
Compound 4 gave a limit, no number; the forecaster's own chance of this, stated with the estimate: 55%; the middle value lies on the limit itself.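

Among the compounds shown here, compound 3 and compound 4 both return only a limit in this assay, so no step between them can be read. The compounds shown leave open whether any chain at this place on the shared core gives a readable number.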